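The source may report more compounds than this note shows. Statements on the series, on what has been measured and on what is new or still open speak of the compounds shown alone.

Among the compounds with values here, in a functional assay on HCT-116 cells (Homo sapiens) for inhibition, read by MTT assay, with a stated time of 48 h (on this read-out higher numbers stand for weaker inhibition and lower numbers for stronger inhibition), compound 1 `COc1ccc(-n2c(SCc3ccccc3)nnc2-c2cc(OC)c(OC)c(OC)c2)cc1` gives 42400 nM, the only actual number so far. Compound 2 `COc1ccc(-n2c(SCC(=O)c3ccccc3)nnc2-c2cc(OC)c(OC)c(OC)c2)cc1` returns only a limit of the assay, > 60000 nM. Compound 3 `COc1ccc(-n2c(SCC(=O)c3ccc(OC)c(O)c3)nnc2-c2cc(OC)c(OC)c(OC)c2)cc1` also returns only a limit, > 60000 nM. Compound 1 thus stands as the sole measured point, set against (the limit of > 60000 nM in this assay, at which 2 of the 3 values shown sit).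

Compound 4 `COc1ccc(-n2c(SCC(=O)c3ccc4ccccc4c3)nnc2-c2cc(OC)c(OC)c(OC)c2)cc1` differs from compound 1 as follows: (naphthalen-2-yl)carbonyl in place of phenyl on a saturated chain carbon bound to a sulfur.

The closest precedents also place an aryl carbonyl group on the saturated chain carbon bound to a sulfur: an at least 1.4-fold higher number from compound 1 to compound 2 (0.15 log units; that floor lies within the scatter), and an at least 1.4-fold higher number from compound 1 to compound 3 (0.15 log units; that floor lies within the scatter). Both are floors and do not go beyond the scatter, but both point towards higher numbers. Going by these compounds, the remaining pair gives a step that the two limits leave unreadable from compound 2 to compound 3, so the effect of changing the aryl group on the carbonyl carbon stays open.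

A modest move to a higher number in this assay is therefore expected, and a result reported only as a limit is quite possible. The estimated step is a 1.4-fold higher number from compound 1 to compound 4 (0.15 log units; within the scatter). Compound 4 is estimated at 60000 nM, with an expected range of 30000 nM to 120000 nM.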

Compound 4, half-maximal inhibitory concentration: > 60000 nM
Compound 4 gave a limit, no number; the forecaster's own chance of this, stated with the estimate: 55%; the middle value sits exactly at the limit.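

Compound 4 is a third aryl carbonyl group on the saturated chain carbon bound to a sulfur that gives only a limit in this assay, so the step is a floor: an at least 1.4-fold higher number from compound 1 to compound 4 (0.15 log units; that floor lies within the scatter). Going to the two six-membered aromatic rings of (naphthalen-2-yl)carbonyl therefore brings no readable number, and the phenyl, 3-hydroxy-4-methoxyphenyl and naphthalen-2-yl groups on the carbonyl carbon all end at the same limit: the limit of > 60000 nM in this assay, at which 3 of the 4 values shown sit. The steps among compound 2, compound 3 and compound 4 cannot be read, as both ends of each are limits.

Going by these compounds, the true values of these three compounds, and so any ranking among them, stay open. Also open, on these data alone, is whether an amine or a carboxylic acid in place of the phenyl on a saturated chain carbon bound to a sulfur would give a number in this assay.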